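Swapping the aryl group at the same aromatic carbon

This account rests on a few compounds, and the source may have more. Where it says the series, first, only, none or still open, it means among the compounds named here.

In a functional assay on SGC-7901 cells (Homo sapiens) for antiproliferative activity, read by MTT assay, with a stated time of 72 h (a lower number here means a stronger inhibitor, a higher number a weaker inhibitor), two compounds sharing one core have been measured. Compound 1 `COc1ccc(-c2ccc3ncn(-c4cc(OC)c(OC)c(OC)c4)c3c2)cc1O` gives 44 nM, while compound 2 `COc1cc(-n2cnc3ccc(-c4ccc([N+](=O)[O-])cc4)cc32)cc(OC)c1OC` gives 79 nM. Among the measured compounds shown here, compound 2 holds the highest of the two numbers, and the one step measured, a 1.8-fold higher number from compound 1 to compound 2 (0.25 log units; within the scatter), shows that the exchange at that position left the two compounds within the scatter of each other. Compound 3 `COc1cccc(-c2ccc3ncn(-c4cc(OC)c(OC)c(OC)c4)c3c2)c1` is not yet measured; it differs from compound 2 in the following way: 3-methoxyphenyl in place of 4-nitrophenyl on an aromatic carbon. For the measured compounds named here, the only step that bears on this change is a 1.8-fold higher number from compound 1 to compound 2 (0.25 log units; within the scatter), which was within the scatter, so another exchange of the aryl group at the same carbon is expected to move the number little, with no direction beyond the scatter predicted. Compound 3 is therefore expected to give about 70 nM, in the range 25 nM to 200 nM, which would be a step of a 1.1-fold lower number from compound 2 to compound 3 (0.05 log units; within the scatter).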

Compound 3, half-maximal inhibitory concentration: 3310 nM
Estimate against measurement, compound 3: 47-fold (1.67 log units) below; the whole stated range lies below it.
By their numbers in this assay, from the lowest: compounds 1 and 2 (each within the scatter of the next); then compound 3.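

In this assay this position turns out not to be indifferent to the aryl group: placing 3-methoxyphenyl on this carbon gives a 42-fold higher number from compound 2 to compound 3 (1.62 log units; beyond the scatter) and, against the other aryl group, a 75-fold higher number from compound 1 to compound 3 (1.88 log units; beyond the scatter) as well. The closeness of compound 1 and compound 2 therefore did not mean that any aryl group is accepted here, since two quite different groups stand within the scatter of each other while 3-methoxyphenyl stands far from both. No measurement at hand accounts for this large step.

The compounds shown leave open whether a plain 4-methoxyphenyl or 3-hydroxyphenyl on this carbon would stay with compound 1 and compound 2 or fall with compound 3. They also leave open how an amine or a carboxylic acid on that phenyl ring would fare.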